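Bromo for acetyl: a step expected within the scatter

The compounds below may be only part of what the source reports. "The series", "measured", "known", "first", "only" and "open" are said of these compounds alone.

Compound 2 `CC(=O)c1ccc(/N=N/N(C)C(=O)NCCSc2ccc(O)cc2)cc1` is the starting point of this step. In an ADME assay on a cell-free system (plasma, Homo sapiens) for metabolic stability, read by HPLC (on this read-out higher numbers stand for a longer-lived compound and lower numbers for a shorter-lived compound), compound 2 gives 61.6 h, the second highest of three numbers. Compound 1 `CN(/N=N/c1ccc(C#N)cc1)C(=O)NCCSc1ccc(O)cc1` gives 74 h in this assay, and compound 3 `CC(=O)c1ccc(/N=N/N(C)C(=O)CCc2ccc(O)cc2)cc1` gives 4.9 h; the gap from compound 2 to compound 3 is beyond the scatter, while the gap to compound 1 is not. Compound 4 `CN(/N=N/c1ccc(Br)cc1)C(=O)NCCSc1ccc(O)cc1` is not yet measured. It differs from compound 2 in one place: bromo in place of acetyl on an aromatic carbon. Within the data shown here, the one measured step that bears on this change is the exchange of the group on the same aromatic carbon, which gave a 1.2-fold lower number from compound 1 to compound 2 (0.08 log units; within the scatter). That swap left the number where it was, so a second swap on that carbon is expected to do the same, with no step beyond the scatter in either direction. Compound 4 is therefore expected to give 65 h, with a range from 35 h to 130 h. The expected step is a 1.1-fold higher number from compound 2 to compound 4 (0.02 log units; within the scatter).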

Compound 4, half-life in the Homo sapiens assay: 105 h
For compound 4 the middle estimate is 1.6-fold (0.21 log units) below the measured one; measured number inside the range.
By their numbers in the Homo sapiens assay, from the lowest: compound 3; then compounds 2, 1 and 4 (each within the scatter of the next).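

In the Homo sapiens assay the aromatic carbon has now carried cyano, acetyl and bromo, and neither new exchange leaves the scatter (a 1.7-fold higher number from compound 2 to compound 4 (0.23 log units; within the scatter); a 1.4-fold higher number from compound 1 to compound 4 (0.15 log units; within the scatter)). So the half-life has so far tolerated three different groups at this place, even with the loss of the acetyl carbonyl. In a physicochemical assay for lipophilicity, read by HPLC, in phosphate buffer, measured as octanol-water partition, with a stated time of 30 min (on this read-out lower numbers stand for lower lipophilicity and higher numbers for higher lipophilicity), compound 2 gives 3.44 and compound 4 gives 3.95 as partition coefficients, which shows that bromo in place of acetyl raises lipophilicity while the half-life stays within the scatter: the measured partition coefficient of compound 2, 3.44, and of compound 4, 3.95, a number 0.51 log units higher (beyond the scatter).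

All three groups are uncharged, so the compounds shown do not tell whether this tolerance extends to an amine or a carboxylic acid on the same carbon. Nor do they tell whether the half-life would hold with a longer chain there.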